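The compounds below may be only part of what the source reports. "The series", "measured", "known", "first", "only" and "open" are said of these compounds alone.

Compound 1 `Cc1cccc(-c2ccccc2OCC2=NCCN2)n1`: 80%
Compound 2 `c1cnc(-c2ccccc2OCC2=NCCN2)nc1`: 90%
Compound 3 `c1ccc(-c2ccsc2)c(OCC2=NCCN2)c1`: 98%

In a functional assay with Alpha-1A adrenergic receptor (Homo sapiens) as the target, read by calcium flux (on this read-out lower numbers stand for smaller maximal responses and higher numbers for larger maximal responses), compound 3 gives the largest of the three numbers; compound 2 sits within the scatter of it, with a number 8 percentage points higher from compound 2 to compound 3 (within the scatter), whereas compound 1 lies beyond the scatter below it. Compound 4 `Cc1ccoc1-c1ccccc1OCC1=NCCN1` is not yet measured. It differs from compound 3 in one place: 3-methylfuran-2-yl in place of thiophen-3-yl on an aromatic carbon. Among the measured compounds shown here, the only measured step that bears on this kind of exchange is the one from compound 2 to compound 3, where one aromatic ring replaced another on the same carbon and the number moved within the scatter. A change of similar size is therefore expected here, with no clear direction beyond the scatter, and compound 4 is estimated at 90% (range 70% to 105%), a step of a number 8 percentage points lower from compound 3 to compound 4 (within the scatter) that is expected to stay within the scatter.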

Compound 4, largest response reached (reported as maximum), in percent of the reference or control that the assay uses: 99%
Compound 4: middle estimate off by 9 percentage points, on the low side, within the range that was stated.
By their numbers in this assay, from the lowest: compounds 1, 2, 3 and 4 (each within the scatter of the next, the first and the last beyond it).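

In this assay, the exchange of thiophen-3-yl for 3-methylfuran-2-yl, which brings a methyl group and puts oxygen in place of sulfur as the ring hetero atom, keeps the maximal response within the scatter (a number 1 percentage points higher from compound 3 to compound 4 (within the scatter)). The same holds against pyrimidin-2-yl (a number 9 percentage points higher from compound 2 to compound 4 (within the scatter)), so this aromatic carbon also accepts a methyl-bearing five-membered ring without a step beyond the scatter. Nothing measured here accounts for this. Going by these compounds, it remains open how an amine, a carboxylic acid or a longer chain on this ring would fare.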